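Hemolysis notes: dropping the methoxy from compound 1

A few compounds are considered here, and "the series" means these few. Any claim that something is new, unique, unknown or untested is made for them only; others in the source may bear on it.

Measured so far:
compound 1, `COc1ccc(-c2ccc(-c3ccc(C(=N)N)o3)o2)cc1`: 71.7%
compound 2, `COc1ccc(-c2ccc(-c3ccc(C(=N)N)s3)s2)cc1`: 92.7%

Both numbers come from an ADME assay on cells (Erythrocyte, Homo sapiens) for activation, read by hemolysis, with a stated time of 30 min, tested at 10 mM; a lower number here means a weaker effect, a higher number a stronger effect of the compound at the concentration tested. Compound 1 stands lowest of the two values at hand; compound 2 sits higher, and the gap between them lies beyond the usual scatter of this assay. Going by the values given here, nothing else has been measured, so no step between compounds that differ in a single place is available, and the gap between compound 1 and compound 2 is simply what the two values show.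

The next compound, compound 3, `N=C(N)c1ccc(-c2ccc(-c3ccccc3)o2)o1`, differs from compound 1 by hydrogen in place of methoxy on an aromatic carbon. The change is a hydrogen in place of methoxy on an aromatic carbon of the six-membered aromatic ring of carbon only, para to a large group.

Among the compounds with values here, with no measured step of this kind to lean on, the expected step of a number 3.7 percentage points lower from compound 1 to compound 3 (within the scatter) is small, within the scatter, and no direction is claimed for it. Compound 3 is expected to give 68%, with a range from 45% to 88%.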

Compound 3, a percentage reported as activity, at one concentration (the size of the read-out at that concentration, not a potency): 66.7%
For compound 3 the middle estimate is 1.3 percentage points above the measured one; measured number inside the range.
By their numbers in this assay, from the lowest: compounds 3 and 1 (each within the scatter of the next); then compound 2.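

In this assay, going by these compounds alone, the step at this position reads a number 5 percentage points lower from compound 1 to compound 3 (within the scatter), the first step between compounds that differ in one place. Hydrogen in place of methoxy on an aromatic carbon, para to a large group, therefore leaves the hemolysis read-out of compound 3 and compound 1 level within the scatter, so at the concentration tested this read-out does not depend on the methoxy in the core of compound 1. No measurement at hand bears on the reason for this result.

On these data alone, a single replacement at one position says little about the position as a whole, so it remains open whether an amine, a carboxylic acid, a fluorine or a longer alkoxy chain such as butoxy would also leave the read-out level. Within the data shown here, it is also open whether hydrogen in place of methoxy would give a step of similar size on the core of compound 2, where the read-out stands at 92.7% and no single-place step is available.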